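The compounds below may be only part of what the source reports. "The series", "measured", "known", "first", "only" and "open" are said of these compounds alone.

Of the compounds shown here, three have been measured in a functional assay on Ehrlich cells (Mus musculus) for cytotoxicity, tested at 50 ug/mL; a lower number here means a weaker effect, a higher number a stronger effect of the compound at the concentration tested. Compound 1 `COc1cc(N2C(N)=C(C#N)C(c3c(O)ccc4ccccc34)C3=C2CC(C)(C)CC3=O)cc(OC)c1OC` gives 15%, compound 2 `COc1cc(N2C(N)=C(C#N)C(c3cccc([N+](=O)[O-])c3)C3=C2CC(C)(C)CC3=O)cc(OC)c1OC` gives 30%, and compound 3 `COc1ccccc1C1C(C#N)=C(N)N(c2cc(OC)c(OC)c(OC)c2)C2=C1C(=O)CC(C)(C)C2` gives 70%. Compound 3 therefore stands highest of the three, with compound 2 nearest to it at a number 40 percentage points higher from compound 2 to compound 3 (beyond the scatter) and compound 1 furthest at a number 55 percentage points higher from compound 1 to compound 3 (beyond the scatter).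

Compound 4 `COc1cc(N2C(N)=C(C#N)C(c3c(OC)ccc4ccccc34)C3=C2CC(C)(C)CC3=O)cc(OC)c1OC` differs from compound 3 in one place: 2-methoxynaphthalen-1-yl in place of 2-methoxyphenyl on a saturated ring carbon. Going by the values given here, of the measured steps, the one from compound 1 to compound 3 bears most on this change, since it also exchanges a naphthalen-1-yl group for a six-membered ring at the same saturated ring carbon, though there the naphthalene carried a hydroxy rather than a methoxy group; that step was a number 55 percentage points higher from compound 1 to compound 3 (beyond the scatter). The step of a number 40 percentage points higher from compound 2 to compound 3 (beyond the scatter) shows as well that compound 3 sits well above the other two. Going back to a naphthalen-1-yl group is thus expected to lower the read-out in this assay, and compound 4 is estimated at 30%, within 10% to 60%, a step of a number 40 percentage points lower from compound 3 to compound 4 (beyond the scatter) that is expected to lie beyond the scatter.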

Compound 4, a percentage reported as activity, at one concentration (the size of the read-out at that concentration, not a potency): 10%
Beside the measured number, compound 4's estimate is 20 percentage points above it, and the stated range covers the measured number.
By their numbers in this assay, from the lowest: compounds 4 and 1 (each within the scatter of the next); then compound 2; then compound 3.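

With the methoxy group kept, adding the second aromatic ring on the saturated ring carbon gives a number 60 percentage points lower from compound 3 to compound 4 (beyond the scatter) in this assay, so the low read-out of the naphthalene compounds does not depend on a free hydroxy group. Methyl in place of hydrogen on that oxygen gives a number 5 percentage points lower from compound 1 to compound 4 (within the scatter), which shows that this exchange has no clear effect here. The result also gives a number 20 percentage points lower from compound 2 to compound 4 (beyond the scatter), so both naphthalene compounds read below the two compounds with a single aromatic ring at this position.

Nothing at hand explains why the larger group lowers the read-out. The compounds shown leave open how an unsubstituted phenyl, a 2-hydroxyphenyl or an unsubstituted naphthalen-1-yl group would read at this position, and whether the same drop would appear at other concentrations.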